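The source may hold more compounds than are shown below. What is called first, only, known or untested is meant among the compounds shown, and "the series" means these compounds.

Going by the values given here, compound 3 `O=C(OCc1ccccc1)N1CCN(C(=S)SCc2cn(Cc3ccccc3F)nn2)CC1` gives 7950 nM in a functional assay on MCF7 cells (Homo sapiens) for inhibition, read by MTT assay, with a stated time of 72 h (a higher number here means a weaker inhibitor, a lower number a stronger inhibitor), the lowest of the three numbers measured so far. Compound 2 `O=C(OCc1ccccc1)N1CCN(C(=S)SCc2cn(Cc3ccc(F)cc3)nn2)CC1` gives 10300 nM in this assay, and a 1.3-fold lower number from compound 2 to compound 3 (0.11 log units; within the scatter). Compound 1 `COc1ccc(Cn2cc(CSC(=S)N3CCN(C(=O)OCc4ccccc4)CC3)nn2)cc1` gives 30500 nM, and a 3.8-fold lower number from compound 1 to compound 3 (0.58 log units; beyond the scatter).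

Compound 4 `COc1cc(Cn2cc(CSC(=S)N3CCN(C(=O)OCc4ccccc4)CC3)nn2)cc(OC)c1OC` is not yet measured. It differs from compound 3 in one place: 3,4,5-trimethoxyphenyl in place of 2-fluorophenyl on a saturated chain carbon bound to an aromatic nitrogen. Among the compounds with values here, two measured steps bear on this change, a 3.8-fold lower number from compound 1 to compound 3 (0.58 log units; beyond the scatter) and a 3.0-fold lower number from compound 1 to compound 2 (0.47 log units; beyond the scatter): in both, a fluorophenyl in place of a methoxy-bearing phenyl gave a lower number. Compound 4 runs the other way, back to a methoxy-bearing phenyl, now with three methoxy groups where compound 1 carried one. A higher number than compound 3 is therefore expected for compound 4, roughly back to the level of compound 1 due to a 3.8-fold lower number from compound 1 to compound 3 (0.58 log units; beyond the scatter), with wide uncertainty since no trimethoxy case has been measured. The expected step is a 3.1-fold higher number from compound 3 to compound 4 (0.50 log units; beyond the scatter). Compound 4 is estimated at 25000 nM, within a range of 8000 nM to 80000 nM.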

Compound 4, half-maximal inhibitory concentration: > 128000 nM
Compound 4 was reported as a limit; the forecaster's own chance of this, stated with the estimate: 10%; middle value at least 5.1-fold (0.70 log units) from the limit.
By their numbers in this assay, from the lowest: compounds 3 and 2 (each within the scatter of the next); then compound 1. At a limit, above all of these: compound 4.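

Compound 4 is reported only as a limit: the limit of > 128000 nM in this assay, at which 1 of the 4 values shown sits.

Going by these compounds alone, at this saturated chain carbon bound to an aromatic nitrogen, 3,4,5-trimethoxyphenyl in place of a fluorophenyl gives an at least 16-fold higher number from compound 3 to compound 4 (1.20 log units; beyond the scatter) and an at least 12-fold higher number from compound 2 to compound 4 (1.09 log units; beyond the scatter), both larger steps than any seen among the earlier compounds. In place of 4-methoxyphenyl, the same group gives an at least 4.1-fold higher number from compound 1 to compound 4 (0.62 log units; beyond the scatter), so in this assay the position responds further when methoxy groups are added to the phenyl, and a single methoxy group did not mark the end of the loss.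

From the compounds shown here alone, the true size of all three steps remains unknown, since each rests on a limit. Also open, going by these compounds, is whether a dimethoxyphenyl falls between compound 1 and compound 4, and how an unsubstituted phenyl, a chlorophenyl or an aminophenyl at this position would compare with compound 3.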